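A Silyl Group in Place of Methyl Across Two Cores

The compounds below may be only part of what the source reports. "The series", "measured", "known", "first", "only" and "open" are said of these compounds alone.

Compound 1 `COc1cc(-c2cc(=O)c3cc(O)ccc3o2)cc(OC)c1OC` and compound 2 `COc1cc(-c2cc(=O)c3ccc(O)cc3o2)cc(OC)c1OC` are built from the same atoms joined differently; the difference between the two cores is not broken down here. In a functional assay on HT-29 cells (Homo sapiens) for cytotoxicity, read by MTT assay, with a stated time of 6 days (a lower number here means that less compound is needed, a higher number that more compound is needed for the effect), compound 1 gives 7.85 ug/mL. Compound 2 reaches only a limit of this assay, > 25 ug/mL, and so has no number. Compound 3 `COc1cc(-c2cc(=O)c3cc(O)ccc3o2)cc(OC)c1O[Si](C)(C)C(C)(C)C` carries a group of 7 heavy atoms (6 carbon, 1 silicon; no ring) in place of one carbon atom, on an oxygen on an aromatic ring relative to compound 1, and in this assay compound 3 gives 2.63 ug/mL, which is a 3.0-fold lower number from compound 1 to compound 3 (0.47 log units; beyond the scatter). Compound 4 `COc1cc(-c2cc(=O)c3ccc(O)cc3o2)cc(OC)c1O[Si](C)(C)C(C)(C)C` carries the same change relative to compound 2, namely (a group of 7 heavy atoms (6 carbon, 1 silicon; no ring) in place of one carbon atom, on an oxygen on an aromatic ring). Because compound 2 sits at the limit of > 25 ug/mL in this assay, at which 1 of the 3 values shown sits, the earlier step can only be carried over in direction. Compound 4 is expected to give about 15 ug/mL, between 5 ug/mL and 40 ug/mL. The expected step, an at least 1.6-fold lower number from compound 2 to compound 4 (0.22 log units; that floor lies within the scatter), rests on a 3.0-fold lower number from compound 1 to compound 3 (0.47 log units; beyond the scatter) and on the limit of compound 2, and may itself end as a limit.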

Compound 4, concentration for half-maximal effect: 1 ug/mL
Compound 4: the middle estimate sits 15-fold (1.18 log units) above what was measured; the measured number lies below the stated range.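

In this assay, the change from methyl to the silicon-bearing group on the oxygen on an aromatic ring gives an at least 25-fold lower number from compound 2 to compound 4 (1.39 log units; beyond the scatter). The direction carries over from one core to the other, but the size does not: the same change on two cores in this assay, a 3.0-fold lower number (0.47 log units; beyond the scatter) from compound 1 to compound 3 and an at least 25-fold lower number (1.39 log units; beyond the scatter) from compound 2 to compound 4, at least 8.3-fold (0.92 log units) apart, beyond the scatter of two such steps Compound 2 is known only through a limit of the assay, so the size of its step is a floor, and two cores set no rule for a third: the limit of > 25 ug/mL in this assay, at which 1 of the 4 values shown sits.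

The compounds shown leave open whether a trimethylsilyl group or a longer alkyl chain on the same oxygen would give a similar step on each core. They also leave open how an amine in place of the free hydroxyl would alter that step.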